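The source may report more compounds than this note shows. Statements on the series, on what has been measured and on what is new or still open speak of the compounds shown alone.

Three compounds share one core and differ only in the group on a carbonyl carbon. In an ADME assay on Caco-2 cells (Homo sapiens) for permeability, in the apical to basolateral direction (on this read-out higher numbers stand for higher permeability and lower numbers for lower permeability), compound 1 `Cn1cncc1CN1CC(N(CC2CCN(C(=O)NC(C)(C)C)CC2)S(=O)(=O)c2ccccn2)Cc2cc(C#N)ccc21` gives 0.6 10^-6 cm/s, compound 2 `Cn1cncc1CN1CC(N(CC2CCN(C(=O)c3ccco3)CC2)S(=O)(=O)c2ccccn2)Cc2cc(C#N)ccc21` gives 0.5 10^-6 cm/s, and compound 3 `CC(C)OC(=O)N1CCC(CN(C2Cc3cc(C#N)ccc3N(Cc3cncn3C)C2)S(=O)(=O)c2ccccn2)CC1` gives 1 10^-6 cm/s, the highest of the three numbers, though the steps of a 1.7-fold higher number from compound 1 to compound 3 (0.22 log units; within the scatter) and a 2.0-fold higher number from compound 2 to compound 3 (0.30 log units; within the scatter) both lie within the scatter, as does a 1.2-fold lower number from compound 1 to compound 2 (0.08 log units; within the scatter). Compound 4 `CC(=O)N1CCC(CN(C2Cc3cc(C#N)ccc3N(Cc3cncn3C)C2)S(=O)(=O)c2ccccn2)CC1` carries methyl in place of isopropoxy on a carbonyl carbon. All three measured steps changed the group on this same carbonyl carbon, and none moved the number beyond the scatter, so no step beyond the scatter is expected here either. Compound 4 is therefore expected to show a 1.1-fold lower number from compound 3 to compound 4 (0.05 log units; within the scatter), an estimate of 0.9 10^-6 cm/s with a range from 0.4 10^-6 cm/s to 2 10^-6 cm/s.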

Compound 4, apparent permeability: 0.5 10^-6 cm/s
Estimate against measurement, compound 4: 1.8-fold (0.26 log units) above; low and high end bracket the measured number.
By their numbers in this assay, from the lowest: compounds 2, 4, 1 and 3 (each within the scatter of the next).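

In this assay, the methyl group gives a 2.0-fold lower number from compound 3 to compound 4 (0.30 log units; within the scatter) and no change at the digits printed from compound 2 to compound 4 (within the scatter) and a 1.2-fold lower number from compound 1 to compound 4 (0.08 log units; within the scatter) and so adds a fourth group at this position without a step beyond the scatter. Even replacing isopropoxy, with 4 heavy atoms, by methyl, with 1 heavy atom, leaves the number within the scatter, so this carbonyl carbon has so far tolerated a group with no oxygen and no ring. On these data alone, whether a longer chain ending in a carboxylic acid would behave the same on this carbonyl carbon remains open. No evidence is available to explain these results.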